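Chloro for fluoro: one small swap on compound 2

This account rests on a few compounds, and the source may have more. Where it says the series, first, only, none or still open, it means among the compounds named here.

compound 1 (`NS(=O)(=O)c1ccc(N2N=C(c3ccccc3)CC2c2ccccc2F)cc1`) gives 28000 nM 
compound 2 (`NS(=O)(=O)c1ccc(N2N=C(c3ccc(Oc4ccccc4)cc3)CC2c2cccc(F)c2)cc1`) gives 28000 nM 

Measured in an ADME assay on Vero 76 cells (Chlorocebus sabaeus) for cytotoxicity, read by MTT assay, with a stated time of 96 h (on this read-out higher numbers stand for lower toxicity in this test and lower numbers for higher toxicity in this test), compound 2 stands level with compound 1, with the same value at the digits shown, so neither ranks ahead. Compound 3 (`NS(=O)(=O)c1ccc(N2N=C(c3ccc(Oc4ccccc4)cc3)CC2c2cccc(Cl)c2)cc1`) differs from compound 2 in one place, with chloro in place of fluoro on an aromatic carbon. Going by the values given here, no measured pair shows this swap on its own, so no shift beyond the scatter is expected in this assay, in either direction. The estimated change a 1.1-fold lower number from compound 2 to compound 3 (0.05 log units; within the scatter) stays within that scatter. For compound 3 the estimate is 25000 nM (expected range 12000 nM to 50000 nM).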

Compound 3, half-maximal cytotoxic concentration: 88000 nM
Compound 3: the middle estimate sits 3.5-fold (0.55 log units) below what was measured; the whole stated range lies below it.
By their numbers in this assay, from the lowest: compounds 1 and 2 (each within the scatter of the next); then compound 3.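

In this assay, the swap from 3-fluorophenyl to 3-chlorophenyl gives a change beyond the usual scatter (a 3.1-fold higher number from compound 2 to compound 3 (0.50 log units; beyond the scatter)). At this ring position, then, exchanging one halogen atom for another is enough to shift the result modestly toward lower toxicity in this test. Nothing available explains this shift. As far as these compounds go, whether a methyl, methoxy or trifluoromethyl group in the same place would raise the number further remains open. This single pair also cannot show whether the same swap would behave alike elsewhere on the ring.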